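This account rests on a few compounds, and the source may have more. Where it says the series, first, only, none or still open, it means among the compounds named here.

Measured compounds:
compound 1 `Cc1c(Oc2ccccc2OCCn2ccc(=O)[nH]c2=O)cc(Cl)c2ccc(C#N)cc12` — > 100000 nM
compound 2 `COCc1cc(Oc2ccccc2OCCn2ccc(=O)[nH]c2=O)c(C)c2cc(C#N)ccc12` — 16000 nM

The two measured compounds share a core and differ at one place. In a toxicity assay on MT2 cells (Homo sapiens) for cytotoxicity, read by MTT assay (on this read-out lower numbers stand for higher toxicity in this test and higher numbers for lower toxicity in this test), compound 1 gives > 100000 nM, which is a limit of the assay and not a number. Compound 2 gives 16000 nM. The step of an at least 6.2-fold lower number from compound 1 to compound 2 (0.79 log units; beyond the scatter) is therefore only an "at least" figure, because compound 1 sits at the limit of > 100000 nM in this assay, at which 1 of the 2 values shown sits.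

Compound 3 `Cc1c(Oc2ccc(F)cc2OCCn2ccc(=O)[nH]c2=O)cc(Cl)c2ccc(C#N)cc12` is not yet measured. It differs from compound 1 by fluoro in place of hydrogen on an aromatic carbon. Among the compounds with values here, the only measured step concerns methoxymethyl in place of chloro, a different change, so no measured step bears on this one. With no evidence pointing either way, no step beyond the scatter is expected, and compound 3 is expected to remain near the limit, as the step of a number no higher from compound 1 to compound 3 (the limit leaves the size open) expresses. Compound 3 is estimated at 100000 nM, within a range from 40000 nM to 300000 nM.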

Compound 3, half-maximal cytotoxic concentration: 82000 nM
Beside the measured number, compound 3's estimate is 1.2-fold (0.09 log units) above it; low and high end bracket the measured number.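

In this assay, within the data shown here, the step of an at least 1.2-fold lower number from compound 1 to compound 3 (0.08 log units; that floor lies within the scatter) is the first reading of a change at this aromatic carbon, which stands meta to a large group and para to a large group. Its floor lies within the scatter, so fluoro in place of hydrogen here shows no clear change in toxicity in this test, though it does not rule one out. For compound 1, > 100000 nM is a limit and not a number, and the true size of this step stays unknown: the limit of > 100000 nM in this assay, at which 1 of the 3 values shown sits.

From the compounds shown here alone, whether an amine or a carboxylic acid at this same carbon would move the number beyond the scatter remains open. Also open, going by these compounds, is whether fluoro at this carbon would behave in the same way with the methoxymethyl group of compound 2 present.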